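Ester chain variation in the calcium channel series

A few compounds are considered here, and "the series" means these few. Any claim that something is new, unique, unknown or untested is made for them only; others in the source may bear on it.

Measured compounds:
compound 1 `CCOC(=O)C1=C(C)NC(C)=C(C(=O)OC)C1c1cnc(SC)n1Nc1ccccc1`: 1.66 nM
compound 2 `COC(=O)C1=C(C)NC(C)=C(C(=O)OC(C)C)C1c1cnc(SC)n1Nc1ccccc1`: 6.35 nM
compound 3 `COC(=O)C1=C(C)NC(C)=C(C(=O)OCCCc2ccccc2)C1c1cnc(SC)n1Nc1ccccc1`: 3.05 nM

In an assay on isolated protein (strain albino) for antagonist activity at Voltage-dependent L-type calcium channel subunit alpha-1C (Cavia porcellus) (on this read-out lower numbers stand for stronger inhibition and higher numbers for weaker inhibition), compound 2 gives the highest number of the three; the gaps a 3.8-fold higher number from compound 1 to compound 2 (0.58 log units; beyond the scatter) and a 2.1-fold lower number from compound 2 to compound 3 (0.32 log units; beyond the scatter) both lie beyond the scatter, so compound 2 is the weakest of the measured set.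

Compound 4 `CSc1ncc(C2C(C(=O)OCC3CCCCC3)=C(C)NC(C)=C2C(=O)OC(C)C)n1Nc1ccccc1` carries cyclohexyl in place of hydrogen on a saturated chain carbon bound to an oxygen next to a carbonyl group. Going by the values given here, two measured steps bear on this. Adding a methyl at the same chain carbon gave a 3.8-fold higher number from compound 1 to compound 2 (0.58 log units; beyond the scatter). Enlarging an ester group gave a 2.1-fold lower number from compound 2 to compound 3 (0.32 log units; beyond the scatter), while a 1.8-fold higher number from compound 1 to compound 3 (0.26 log units; within the scatter) stayed within the scatter. The ester enlargement in compound 4 is therefore expected to give a modest lowering, a 1.8-fold lower number from compound 2 to compound 4 (0.26 log units; within the scatter). For compound 4 the estimate in this assay is 3.5 nM, with a range from 1.5 nM to 8 nM.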

Compound 4, half-maximal inhibitory concentration: 56 nM
Beside the measured number, compound 4's estimate is 16-fold (1.20 log units) below it; measured number outside the range, above it.
By their numbers in this assay, from the lowest: compounds 1 and 3 (each within the scatter of the next); then compound 2; then compound 4.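

In this assay, changing methoxycarbonyl to cyclohexylmethoxycarbonyl while the isopropyl ester stays in place gives an 8.8-fold higher number from compound 2 to compound 4 (0.95 log units; beyond the scatter). This position is therefore not open to any enlargement, whereas the change of isopropyl to 3-phenylpropyl at the other ester gave a 2.1-fold lower number from compound 2 to compound 3 (0.32 log units; beyond the scatter). No supporting data bear on the reason for this loss.

The compounds shown leave open whether the loss belongs to the cyclohexyl ring itself or would also follow from a straight hexyl chain. On these data alone, an amine at the end of the chain at this position also remains untested here.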